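Nitro for bromo on the benzyl ether of compound 3

The source may hold more compounds than are shown below. What is called first, only, known or untested is meant among the compounds shown, and "the series" means these compounds.

Three compounds have been measured in an ADME assay on Huh-5-2 cells (Homo sapiens) for cytotoxicity, read by WST assay, with a stated time of 3 days; a higher number here means that more compound is tolerated, a lower number that less compound is tolerated:
Compound 1 `O=c1c(O)c(-c2ccccc2)oc2cc(OCc3ccccc3Cl)cc(O)c12`: > 100000 nM
Compound 2 `N#Cc1ccccc1COc1cc(O)c2c(=O)c(O)c(-c3ccccc3)oc2c1`: 22000 nM
Compound 3 `O=c1c(O)c(-c2ccccc2)oc2cc(OCc3cccc(Br)c3)cc(O)c12`: > 100000 nM

Compound 3 reports only a limit in this assay, not a number. The same is true of compound 1 (the limit of > 100000 nM in this assay, at which 2 of the 3 values shown sit). The next compound, compound 4 `O=c1c(O)c(-c2ccccc2)oc2cc(OCc3cccc([N+](=O)[O-])c3)cc(O)c12`, differs from compound 3 by nitro in place of bromo on an aromatic carbon. Among the measured compounds shown here, two measured steps bear on this: an at least 4.5-fold lower number from compound 1 to compound 2 (0.65 log units; beyond the scatter), and an at least 4.5-fold higher number from compound 2 to compound 3 (0.65 log units; beyond the scatter). For the measured compounds named here, putting a nitro group where the bromo stood is untested, so the direction is open, but the one clear change among the three, the entry of cyano, lowered the number. Compound 4 is therefore expected to give roughly 40000 nM, between 10000 nM and 100000 nM, an estimated step of an at least 2.5-fold lower number from compound 3 to compound 4 (0.39 log units; beyond the scatter).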

Compound 4, half-maximal cytotoxic concentration: 76000 nM
For compound 4 the middle estimate is 1.9-fold (0.28 log units) below the measured one, and the stated range covers the measured number.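

At this place on the ring, the 3-nitrophenyl group gives a real number in this assay, and it shows an at least 1.3-fold lower number from compound 3 to compound 4 (0.11 log units; that floor lies within the scatter), alongside an at least 1.3-fold lower number from compound 1 to compound 4 (0.11 log units; that floor lies within the scatter). Neither step shows a real change, whereas the 2-cyanophenyl group stands clearly apart, with a 3.5-fold higher number from compound 2 to compound 4 (0.54 log units; beyond the scatter). Compound 1 and compound 3 each report a limit, not a number: the limit of > 100000 nM in this assay, at which 2 of the 4 values shown sit.

Going by these compounds, how far compound 3 truly lies from compound 4 remains unknown. Also open, on these data alone, is whether an amine or a carboxylic acid at this place would lower the number as far as compound 2 does.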